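The source may hold more compounds than are shown below. What is called first, only, known or untested is meant among the compounds shown, and "the series" means these compounds.

Measured so far in a physicochemical assay for acid dissociation, using potentiometric titration:
Compound 1, `N#C/C(=N\O)C(=O)Nc1cc(C(F)(F)F)cc(C(F)(F)F)c1`, gives 4.73.
Compound 2, `N#C/C(=N\O)C(=O)Nc1cccc(F)c1`, gives 4.92.
Compound 3, `N#C/C(=N\O)C(=O)Nc1ccccc1F`, gives 4.87.

All three share the same core and differ only in what sits on the aromatic ring. Among these three numbers compound 3 lies closest to compound 2 and farthest from compound 1, yet both gaps fall within the scatter of this assay, so the three compounds cannot be told apart on these data.

The next compound, compound 4, `N#C/C(=N\O)C(=O)Nc1ccccc1`, has not yet been measured in this assay. It differs from compound 3 in one place: hydrogen in place of fluoro on an aromatic carbon. For the measured compounds named here, no step of this kind has been measured here, so the expectation rests on the three values alone, which sit close together despite quite different substitution. Compound 4 is therefore expected to give a number near the others, with the step from compound 3 to compound 4 estimated at a number 0.13 log units higher from compound 3 to compound 4 (within the scatter), upward if anything, and likely within the scatter. For compound 4 the estimate in this assay is 5, expected to fall from 4.75 to 5.25.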

Compound 4, acid dissociation constant: 5.12
Estimate against measurement, compound 4: 0.12 log units below, and the stated range covers the measured number.
By their numbers in this assay, from the lowest: compounds 1, 3, 2 and 4 (each within the scatter of the next, the first and the last beyond it).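

Hydrogen in place of fluoro on an aromatic carbon, ortho to a group of 8 heavy atoms, gives a number 0.25 log units higher from compound 3 to compound 4 (within the scatter) in this assay on the first measured pair that differs in one place. The same exchange on another aromatic carbon gives a number 0.20 log units higher from compound 2 to compound 4 (within the scatter) in this read-out, so at neither place does the fluoro separate from hydrogen, and the two places cannot be told apart. Nothing at hand explains these small steps.

The compounds shown leave open whether a group of another kind on the aromatic ring, such as an amine, a methoxy group or a carboxylic acid, would shift the number beyond the scatter. They also leave open whether replacing the nitrile of the shared core would do so.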